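Swapping Methoxy for Fluoro on a Furan Amidine

The compounds below may be only part of what the source reports. "The series", "measured", "known", "first", "only" and "open" are said of these compounds alone.

Measured compounds:
compound 1 `COc1ccc(-c2ccc(-c3ccc(C(=N)N)o3)o2)cc1`, 5710 nM
compound 2 `N=C(N)c1ccc(-c2ccc(-c3cncc4ccccc34)s2)s1`, 2000 nM
compound 3 `COc1cc(OC)cc(-c2ccc(-c3ccc(C(=N)N)o3)o2)c1`, 2440 nM

All three were tested in a functional assay on SK-MEL-2 cells (Homo sapiens) for inhibition, read by sulforhodamine B assay, with a stated time of 48 h; a higher number here means a weaker inhibitor of growth, a lower number a stronger inhibitor of growth. Among them compound 1 gives the highest number, 5710 nM, and is therefore the weakest growth inhibitor of the set. Its closest neighbour is compound 3, with 2440 nM, a difference beyond the usual scatter, and the furthest is compound 2, with 2000 nM, also beyond the scatter.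

The step followed here leads from compound 1 to compound 4 `N=C(N)c1ccc(-c2ccc(-c3ccc(F)cc3)o2)o1`, which has not yet been measured. The change is fluoro in place of methoxy on an aromatic carbon. For the measured compounds named here, no pair of measured compounds differing in one place is available, so there is no directly comparable step. Compound 3 carries two methoxy groups and reads lower than compound 1, but that says little about replacing one methoxy by fluoro. The expectation for this assay is a step of modest size, most likely none beyond the scatter, with a slight lean toward a weaker inhibitor.

Compound 4 is therefore expected to give about 6500 nM, within 2500 nM to 17000 nM. The step from compound 1 to compound 4 is estimated at a 1.1-fold higher number from compound 1 to compound 4 (0.06 log units; within the scatter).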

Compound 4, concentration for 50% growth inhibition: 1760 nM
Compound 4: the middle estimate sits 3.7-fold (0.57 log units) above what was measured, and the stated range ends above it.
By their numbers in this assay, from the lowest: compounds 4, 2 and 3 (each within the scatter of the next); then compound 1.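

In this assay, fluoro in place of methoxy on an aromatic carbon, para to a large group, gives a 3.2-fold lower number from compound 1 to compound 4 (0.51 log units; beyond the scatter). For the compounds shown here, this is the first single-place comparison in the set, and it shows that growth inhibition responds to the group at this position. It also shows that the methoxy group is not required there for activity in these cells, and that its removal with fluoro entering leads to a stronger growth inhibitor rather than a weaker one. Nothing available explains why this exchange has this effect, and the conclusion rests on this one pair of compounds.

From the compounds shown here alone, it remains open how other groups at this position would compare with fluoro and methoxy, for example chloro, hydroxyl, an amine or a plain hydrogen, and whether any of them would move the number further in the same direction. Going by these compounds, it is also open whether the same exchange would produce a step of similar size on a different core.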